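Swapping a Thiazole for a Chloroimidazole on One Core

The source may report more compounds than this note shows. Statements on the series, on what has been measured and on what is new or still open speak of the compounds shown alone.

Compound 1 `COCCC[S+]([O-])c1sc2nc(-c3nccs3)cc(-c3cnc(C)n3C)c2c1N` gives 3.3 nM
Compound 2 `CCCC[S+]([O-])c1sc2nc(-c3nccs3)cc(-c3nccs3)c2c1N` gives 1.8 nM
Compound 3 `CCC[S+]([O-])c1sc2nc(-c3nccs3)cc(C)c2c1N` gives 5.3 nM

Of the compounds shown here, three sharing one core have been tested in an assay for inhibition of 15-hydroxyprostaglandin dehydrogenase [NAD(+)] (Homo sapiens), read by fluorescence, with a stated time of 15 min, in the presence of a further agent that is not named here; on this read-out lower numbers stand for stronger inhibition and higher numbers for weaker inhibition. Compound 2 gives the lowest number of the three, 1.8 nM. Compound 1 stays within the usual scatter of that, at 3.3 nM, so the two cannot be ranked; compound 3, at 5.3 nM, lies beyond the scatter. Compound 4 `CCCC[S+]([O-])c1sc2nc(-c3nccs3)cc(-c3cnc(Cl)n3C)c2c1N` is the next step from compound 2: 2-chloro-1-methyl-1H-imidazol-5-yl in place of 1,3-thiazol-2-yl on an aromatic carbon. Going by the values given here, no measured pair shows this exact change, so the expectation leans on compound 1, which carries a related imidazolyl group and gives 3.3 nM in this assay. A small step, if any, is expected, likely toward a slightly higher number. Compound 4 is therefore estimated at 3 nM, within a range of 1 nM to 9 nM. The expected step is a 1.7-fold higher number from compound 2 to compound 4 (0.22 log units; within the scatter).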

Compound 4, half-maximal inhibitory concentration: 3.2 nM
Compound 4: middle estimate off by 1.1-fold (0.03 log units), on the low side; low and high end bracket the measured number.
By their numbers in this assay, from the lowest: compounds 2, 4, 1 and 3 (each within the scatter of the next, the first and the last beyond it).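

In this assay, placing 2-chloro-1-methyl-1H-imidazol-5-yl in place of 1,3-thiazol-2-yl, opposite the ring nitrogen, gives a 1.8-fold higher number from compound 2 to compound 4 (0.25 log units; within the scatter). At this position of the shared core, then, a group of seven heavy atoms scores like one of five, so the extra chlorine and methyl carry no cost that this assay can detect. No measurement here explains why the two groups read alike. Still open, from the compounds shown here alone, is how a phenyl ring, an amine or a carboxylic acid would read at this position, and whether the chlorine itself matters.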